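A few compounds are considered here, and "the series" means these few. Any claim that something is new, unique, unknown or untested is made for them only; others in the source may bear on it.

In an assay on CHO cells for displacement of a labelled ligand from adenosine receptor A1 (Homo sapiens), read by scintillation counting, tested at 10 uM (on this read-out lower numbers stand for less inhibition and higher numbers for more inhibition at the one concentration tested (going by the name of the read-out)), compound 1 `CC(C)(C)Cc1csc(N)c1C(=O)c1ccc(Cl)cc1` gives 1%, and compound 2 `Cc1cccc(-c2sc(N)c(C(=O)c3ccc(Cl)cc3)c2CC(C)(C)C)c1` gives 1%, while compound 3 `CC(C)c1ccc(-c2sc(N)c(C(=O)c3ccc(Cl)cc3)c2CC(C)(C)C)cc1` gives 1%; compound 1 therefore stands level with both. The steps of no change at the digits printed from compound 1 to compound 2 (within the scatter) and no change at the digits printed from compound 1 to compound 3 (within the scatter) show that adding an aryl group to the shared core leaves this assay flat. Compound 4 `CC(C)(C)Cc1csc(N)c1C(=O)c1ccc(Cl)c(Cl)c1` differs from compound 1 by chloro in place of hydrogen on an aromatic carbon, a change on a different part of the molecule. For the measured compounds named here, no measured step touches that ring, so none bears on it directly; the only guidance is that every change so far, from compound 1 to compound 2 and from compound 1 to compound 3, stayed within the scatter. Compound 4 is thus expected at 3%, within 0% to 15%, a step of a number 2 percentage points higher from compound 1 to compound 4 (within the scatter).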

Compound 4, a percentage reported as inhibition, at one concentration (the size of the read-out at that concentration, not a potency): 1%
Beside the measured number, compound 4's estimate is 2 percentage points above it, and the stated range covers the measured number.
By their numbers in this assay, from the lowest: compounds 1, 2, 3 and 4 (each within the scatter of the next).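

In this assay, chloro in place of hydrogen on the six-membered aromatic ring, ortho to a chloro group, brings no change at the digits printed from compound 1 to compound 4 (within the scatter). This extends the flat picture from the aryl groups of compound 2 and compound 3 to a change on this ring, which those compounds left untouched. No available evidence bears on this result. From the compounds shown here alone, whether an amine or a carboxylic acid at this place would move the read-out stays open, as does whether the added chloro would behave alike on compound 2 or compound 3.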